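The source may hold more compounds than are shown below. What is called first, only, known or untested is meant among the compounds shown, and "the series" means these compounds.

Values so far in a functional assay on MCF7 cells (Homo sapiens) for antiproliferative activity, read by MTT assay, with a stated time of 72 h; a higher number here means a weaker inhibitor, a lower number a stronger inhibitor

- Compound 1 `O=S(=O)(Oc1ccccc1)C1CC2OC1C(c1ccc(/C=C/c3cc(O)cc(O)c3)cc1)=C2c1ccc(O)cc1` gives 20100 nM
- Compound 2 `Cc1ccccc1OS(=O)(=O)C1CC2OC1C(c1ccc(/C=C/c3cc(O)cc(O)c3)cc1)=C2c1ccc(O)cc1` gives 55800 nM
- Compound 3 `O=S(=O)(Oc1ccccc1C(F)(F)F)C1CC2OC1C(c1ccc(/C=C/c3cc(O)cc(O)c3)cc1)=C2c1ccc(O)cc1` gives 18300 nM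

Compound 3 sits in the low pair of these numbers (a 1.1-fold lower number from compound 1 to compound 3 (0.04 log units; within the scatter)) and clear of the remaining value (a 3.0-fold lower number from compound 2 to compound 3 (0.48 log units; beyond the scatter)). The next change gives compound 4 `O=S(=O)(Oc1cccc(Cl)c1)C1CC2OC1C(c1ccc(/C=C/c3cc(O)cc(O)c3)cc1)=C2c1ccc(O)cc1`, with 3-chlorophenyl in place of 2-(trifluoromethyl)phenyl on an oxygen. Substitution on the phenyl group has so far moved the number modestly (a 2.8-fold higher number from compound 1 to compound 2 (0.44 log units; beyond the scatter)) or not beyond the scatter (a 1.1-fold lower number from compound 1 to compound 3 (0.04 log units; within the scatter)). Among the measured compounds shown here, no measured compound carries chlorine, so these steps are only a loose guide. No step beyond the scatter is therefore expected in this assay (a 1.1-fold lower number from compound 3 to compound 4 (0.03 log units; within the scatter)). For compound 4 the estimated value is 17000 nM with an expected range (7000 nM to 50000 nM).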

Compound 4, half-maximal inhibitory concentration: 12900 nM
For compound 4 the middle estimate is 1.3-fold (0.12 log units) above the measured one; measured number inside the range.
By their numbers in this assay, from the lowest: compounds 4, 3 and 1 (each within the scatter of the next); then compound 2.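

In this assay, 3-chlorophenyl, the only chlorine-bearing group shown on this oxygen, stays within the scatter of the unsubstituted phenyl (a 1.6-fold lower number from compound 1 to compound 4 (0.19 log units; within the scatter)) and of 2-(trifluoromethyl)phenyl (a 1.4-fold lower number from compound 3 to compound 4 (0.15 log units; within the scatter)). Among the compounds shown here, only the step from 2-methylphenyl lies beyond the scatter (a 4.3-fold lower number from compound 2 to compound 4 (0.64 log units; beyond the scatter)), so compound 2 alone stands apart among the four. Nothing on hand accounts for these values. Open, on these data alone, is whether an amine or a carboxylic acid on this phenyl group would move the number beyond the scatter of compound 1, and whether 2-chlorophenyl would track 3-chlorophenyl or 2-methylphenyl.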